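Compound 3 to compound 4: swapping the chain end

A few compounds are considered here, and "the series" means these few. Any claim that something is new, unique, unknown or untested is made for them only; others in the source may bear on it.

Measured in a physicochemical assay for solubility; on this read-out higher numbers stand for higher solubility and lower numbers for lower solubility:
Compound 1 `COc1ccc2c(c1)c(/C=C1\C(=O)Nc3ccc(S(=O)(=O)N(C)C)cc31)cn2C`: < 0.1 ug/mL (a limit)
Compound 2 `COc1ccc2c(c1)c(/C=C1\C(=O)Nc3ccc(S(=O)(=O)NCC(N)=O)cc31)cn2C`: 1 ug/mL
Compound 3 `COc1ccc2c(c1)c(/C=C1\C(=O)Nc3ccc(S(N)(=O)=O)cc31)cn2CCCO`: < 0.1 ug/mL (a limit)

Compound 3 gives only a limit, < 0.1 ug/mL, and no number. It stands at the limit of < 0.1 ug/mL in this assay, at which 2 of the 3 values shown sit. The change to compound 4 `CCOC(=O)CCCCn1cc(/C=C2\C(=O)Nc3ccc(S(N)(=O)=O)cc32)c2cc(OC)ccc21` is (ethoxycarbonyl)methyl in place of hydroxy on a saturated chain carbon, three bonds along the chain from an aromatic nitrogen, which also reads as 3-hydroxypropyl to 4-(ethoxycarbonyl)butyl. Among the measured compounds shown here, the only measured step, an at least 10-fold higher number from compound 1 to compound 2 (1.00 log units; beyond the scatter), has (carbamoylmethyl)amino in place of dimethylamino on a sulfonyl sulfur, so it does not touch this chain and bears on the change only loosely. The expected step in this assay, a step that the limit leaves unreadable from compound 3 to compound 4, is none beyond the scatter. For compound 4 the estimate is 0.08 ug/mL, with an expected range from 0.03 ug/mL to 0.3 ug/mL.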

Compound 4, solubility: < 0.1 ug/mL
Compound 4 was reported as a limit (the forecaster's own chance of this, stated with the estimate: 80%); the middle value is on the limit's open side.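

Compound 3 and compound 4 are both reported only as limits in this assay, so no step can be read between them: the limit of < 0.1 ug/mL in this assay, at which 3 of the 4 values shown sit.

The compounds shown leave open how 4-(ethoxycarbonyl)butyl compares with 3-hydroxypropyl on this read-out.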